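Swapping an Allyl for an Isobutyl on the Amide

The compounds below may be only part of what the source reports. "The series", "measured", "known", "first", "only" and "open" are said of these compounds alone.

Of the compounds shown here, three have so far been tested in a functional assay on the whole organism for inhibition, with Brassica rapa subsp. chinensis as the target, with a stated time of 3 days, tested at 100 ppm; a lower number here means less inhibition of growth, a higher number more inhibition of growth at the concentration tested. Compound 1 `C=CCNC(=O)/C=C/c1ccccc1` gives 64%, the highest of the three numbers. Compound 2 `CCCCCCCCCCNC(=O)/C=C/c1ccccc1` gives 15% in this assay, a figure far below compound 1 and beyond the usual scatter. Compound 3 `C=CCc1ccc(OC(=O)/C=C/c2ccc(C(C)C)cc2)c(OC)c1` gives 0% in this assay, furthest of all from compound 1. Compound 4 `CC(C)CNC(=O)/C=C/c1ccccc1` has not yet been measured; it differs from compound 1 by isopropyl in place of vinyl on a saturated chain carbon bound to an amide-type nitrogen. Going by the values given here, no two measured compounds differ in only one place, so no measured step guides this change. The expected step from compound 1 to compound 4 in this assay is a modest drop, a number 14 percentage points lower from compound 1 to compound 4 (beyond the scatter), small beside the fall seen with compound 2. Compound 4 is therefore estimated at 50%, within a range from 25% to 75%.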

Compound 4, percent growth inhibition at one concentration: 78%
Estimate against measurement, compound 4: 28 percentage points below; measured number outside the range, above it.
By their numbers in this assay, from the lowest: compound 3; then compound 2; then compound 1; then compound 4.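

Changing allyl to isobutyl on a saturated chain carbon bound to an amide-type nitrogen gives a number 14 percentage points higher from compound 1 to compound 4 (beyond the scatter) and so shows that, in this pair, growth inhibition does not depend on the double bond of the allyl. A saturated group with one more carbon is accepted at this place, and the number even rises.

Still open, as far as these compounds go, is how a hydroxyl, an amine or a cyclopropylmethyl group would fare at the same place on the shared core. No measurement at hand explains the rise.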